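A few compounds are considered here, and "the series" means these few. Any claim that something is new, unique, unknown or untested is made for them only; others in the source may bear on it.

Measured so far:
Compound 1 `CCOC(=O)[C@@H]1CCCN(S(=O)(=O)c2ccc(S(=O)(=O)N3CCOCC3)cc2)C1` gives 23500 nM in a functional assay on MIA PaCa-2 cells (Homo sapiens) for inhibition, read by MTT assay, with a stated time of 7 days; on this read-out lower numbers stand for stronger inhibition and higher numbers for weaker inhibition.
Compound 2 `CCOC(=O)[C@@H]1CCC[C@H](S(=O)(=O)c2ccc(S(=O)(=O)N(CC)CC)cc2)C1` gives 21500 nM in this assay.

Compound 1 stands at the upper of these two numbers, but the gap to compound 2 is within the scatter, so no order between the two is claimed. Compound 3 `CCOC(=O)[C@@H]1CCCN(S(=O)(=O)c2ccc(S(=O)(=O)N(CC)C(C)C)cc2)C1` is the unmeasured analogue; it arises from compound 1 by ethyl(isopropyl)amino in place of morpholin-4-yl on a sulfonyl sulfur. Within the data shown here, no step between measured compounds calibrates this change. Among the measured compounds shown here, compound 2 carries an open-chain dialkylamino group on its sulfonyl sulfur too, yet it also differs in how its core is joined to the sulfonyl, so its value shows only that such a group has been tolerated at the same level. The expected step is small, if anything toward a lower number, and likely within the scatter: a 1.3-fold lower number from compound 1 to compound 3 (0.12 log units; within the scatter). Compound 3 is expected at 18000 nM, within 7000 nM to 45000 nM.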

Compound 3, half-maximal inhibitory concentration: 1000 nM
Beside the measured number, compound 3's estimate is 18-fold (1.26 log units) above it, outside the stated range (below it).
By their numbers in this assay, from the lowest: compound 3; then compounds 2 and 1 (each within the scatter of the next).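

In this assay, the group on a sulfonyl sulfur proves decisive: ethyl(isopropyl)amino in place of morpholin-4-yl gives a 24-fold lower number from compound 1 to compound 3 (1.37 log units; beyond the scatter) on an otherwise unchanged structure. Among these compounds, the change keeps the heavy-atom count but removes the ring and its oxygen, so a sharp dependence on this group appears, which the earlier compounds could not show as compound 2 also differs in how its core is joined to the sulfonyl. Nothing at hand indicates which feature of the change carries this step.

As far as these compounds go, it remains open whether loss of the ring or loss of the oxygen matters more; piperidin-1-yl or diethylamino on the core of compound 1 would separate the two. Also open, from the compounds shown here alone, is how a carboxylic acid in place of the ethyl ester would fare with ethyl(isopropyl)amino kept.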